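Swapping Chloro for Trifluoromethyl on the Pendant Phenyl

A few compounds are considered here, and "the series" means these few. Any claim that something is new, unique, unknown or untested is made for them only; others in the source may bear on it.

Of the compounds shown here, three built on one shared core have been tested in an assay on CHO-K1 cells for displacement of a labelled ligand from adenosine receptor A1 (Homo sapiens), tested at 10 uM; a lower number here means less inhibition, a higher number more inhibition at the concentration tested (going by the name of the read-out). Compound 1 `CCOC(=O)c1c(N)sc(-c2ccccc2)c1-c1cccc(C(F)(F)F)c1` gives 83.6%. Compound 2 `CCOC(=O)c1c(N)sc(-c2cccc(C(C)=O)c2)c1-c1cccc(C(F)(F)F)c1` gives 68.9%. Compound 3 `CCOC(=O)c1c(N)sc(-c2ccc(Cl)cc2)c1-c1cccc(C(F)(F)F)c1` gives 58.4%, the lowest of the three numbers; compound 2 stands nearest to it and compound 1 furthest. The measured steps are a number 14.7 percentage points lower from compound 1 to compound 2 (beyond the scatter), a number 25.2 percentage points lower from compound 1 to compound 3 (beyond the scatter) and a number 10.5 percentage points lower from compound 2 to compound 3 (beyond the scatter).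

Compound 4 `CCOC(=O)c1c(N)sc(-c2ccc(C(F)(F)F)cc2)c1-c1cccc(C(F)(F)F)c1` differs from compound 3 in one place: trifluoromethyl in place of chloro on an aromatic carbon. Read one bond further out, 4-chlorophenyl becomes 4-(trifluoromethyl)phenyl, the new group sitting para to a large group. Among the measured compounds shown here, no measured step exchanges chloro for trifluoromethyl, so there is no direct guide. What the steps do show is that adding a group to this phenyl ring, whether acetyl in compound 2 or chloro in compound 3, lowered inhibition relative to the unsubstituted compound 1, and the bulkier chloro gave the larger drop. Trifluoromethyl brings more heavy atoms than chloro, so a further small drop, or a step within the scatter, is expected: a number 8.4 percentage points lower from compound 3 to compound 4 (within the scatter). Compound 4 is therefore estimated at 50%, in a range from 32% to 68%.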

Compound 4, a percentage reported as inhibition, at one concentration (the size of the read-out at that concentration, not a potency): 48.5%
The estimate for compound 4 lay 1.5 percentage points above the measured number, and the stated range covers the measured number.
By their numbers in this assay, from the lowest: compounds 4 and 3 (each within the scatter of the next); then compound 2; then compound 1.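

In this assay, trifluoromethyl in place of chloro, para to a large group, gives a number 9.9 percentage points lower from compound 3 to compound 4 (within the scatter) and so leaves the two groups indistinguishable here, even though trifluoromethyl brings 4 heavy atoms where chloro brings 1. The unsubstituted phenyl of compound 1 now stands further apart, with a number 35.1 percentage points lower from compound 1 to compound 4 (beyond the scatter) as the largest step in the set, while the swap from 3-acetylphenyl to 4-(trifluoromethyl)phenyl gives a number 20.4 percentage points lower from compound 2 to compound 4 (beyond the scatter) as a result that changes both the group and its place on the ring. Nothing measured here explains why these groups lower the read-out.

On these data alone, two different groups at this position now give numbers within the scatter of each other, but it remains open whether a fluoro, a methoxy, an amine or a carboxylic acid at the same place would fit that picture or come closer to compound 1. As far as these compounds go, it is also open whether chloro or trifluoromethyl placed where the acetyl of compound 2 sits would give a different number, which would separate the effect of the group from the effect of its place on the ring.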